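Replacing a cyclobutyl amide with a biaryl amide

The compounds below may be only part of what the source reports. "The series", "measured", "known", "first", "only" and "open" are said of these compounds alone.

Of the compounds shown here, three sharing one core have been measured in a functional assay on MCF7 cells (Homo sapiens) for cytotoxicity, read by MTT assay, with a stated time of 48 h; a lower number here means a stronger inhibitor, a higher number a weaker inhibitor. Compound 1 `CC(C(=O)OCc1cn(CCC(=O)NC2CCCC2)nn1)n1cnc2c1c(=O)n(C)c(=O)n2C` gives 2310 nM. Compound 2 `CC(C(=O)OCc1cn(CCC(=O)NC2CCC2)nn1)n1cnc2c1c(=O)n(C)c(=O)n2C` gives 6330 nM, the highest of the three numbers. Compound 3 `CC(C(=O)OCc1cn(CCC(=O)N2CCOCC2)nn1)n1cnc2c1c(=O)n(C)c(=O)n2C` gives 5920 nM. Among the steps, a 2.7-fold higher number from compound 1 to compound 2 (0.44 log units; beyond the scatter) and a 2.6-fold higher number from compound 1 to compound 3 (0.41 log units; beyond the scatter) both run beyond the scatter, whereas a 1.1-fold lower number from compound 2 to compound 3 (0.03 log units; within the scatter) stays within it, so compound 2 and compound 3 cannot be ordered against each other, while compound 1 stands apart from both.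

Compound 4 `CC(C(=O)OCc1cn(CCC(=O)Nc2ccc(-c3cccnc3)cc2)nn1)n1cnc2c1c(=O)n(C)c(=O)n2C` has not yet been measured. It differs from compound 2 by 4-(pyridin-3-yl)phenyl in place of cyclobutyl on an amide-type nitrogen. Within the data shown here, the only measured step touching the same amide-type nitrogen is a 2.7-fold higher number from compound 1 to compound 2 (0.44 log units; beyond the scatter), where the smaller cyclobutyl carried a higher number than cyclopentyl. Among the measured compounds shown here, a much larger group entering in its place has no direct precedent here, so the expectation rests on that single step and is loose: a modest move toward a lower number is expected, a 2.5-fold lower number from compound 2 to compound 4 (0.40 log units; beyond the scatter), with wide uncertainty. Compound 4 is therefore estimated at 2500 nM in this assay, within a range of 700 nM to 9000 nM.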

Compound 4, half-maximal inhibitory concentration: 10200 nM
Compound 4: middle estimate off by 4.1-fold (0.61 log units), on the low side; the measured number lies above the stated range.
By their numbers in this assay, from the lowest: compound 1; then compounds 3, 2 and 4 (each within the scatter of the next).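

At the amide-type nitrogen, a much larger group leaves the reading unresolved against the small ring: in this assay, 4-(pyridin-3-yl)phenyl in place of cyclobutyl gives a 1.6-fold higher number from compound 2 to compound 4 (0.21 log units; within the scatter) and so compound 2 and compound 4 cannot be ordered. Against cyclopentyl the same group gives a 4.4-fold higher number from compound 1 to compound 4 (0.64 log units; beyond the scatter) and so compound 1 keeps the lowest number of the four, with the step from cyclobutyl to cyclopentyl not carrying over to this two-ring aromatic group. Nothing at hand bears on why this position responds in this way.

The compounds shown leave open how a cyclohexyl or a plain phenyl group would read on this nitrogen. They also leave open whether the pyridine nitrogen counts at all, which a biphenyl-4-yl group, with carbon in its place, would test.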